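The compounds below may be only part of what the source reports. "The series", "measured", "known", "first", "only" and "open" are said of these compounds alone.

Measured in a functional assay on BT-483 cells (Homo sapiens) for cytotoxicity, read by MTT assay, with a stated time of 24 h; on this read-out lower numbers stand for stronger inhibition and higher numbers for weaker inhibition:
Compound 1 `CCNc1cc(-c2ccc(NC(=O)Nc3ccc(OC)cc3)cc2C)ccn1`: 25800 nM
Compound 2 `CCNc1cc(-c2ccc(NC(=O)Nc3c(C)cccc3C)cc2C)ccn1`: > 30000 nM, a limit of the assay and not a number
Compound 3 `CCNc1cc(-c2ccc(NC(=O)Nc3ccc(OC)cc3)cc2C(F)(F)F)ccn1`: 17600 nM

Among the compounds with values here, compound 3 and compound 1 hold the only two actual numbers, and these lie within the scatter of each other. Compound 4 `CCNc1cc(-c2ccc(NC(=O)Nc3c(C)cccc3C)cc2C(F)(F)F)ccn1` keeps the trifluoromethyl of compound 3 but differs from it as follows: 2,6-dimethylphenyl in place of 4-methoxyphenyl on an amide-type nitrogen. The same swap, made on the methyl-bearing partner, gave an at least 1.1-fold higher number from compound 1 to compound 2 (0.06 log units; that floor lies within the scatter). On these data alone, that figure is only a floor, set by the limit of > 30000 nM in this assay, at which 1 of the 3 values shown sits, so the true size of the step remains open. The other measured step, a 1.5-fold lower number from compound 1 to compound 3 (0.17 log units; within the scatter), exchanges methyl for trifluoromethyl. A modest rise in this assay is therefore expected, or none beyond the scatter, and the result may be reported only as a limit. The expected change is a 1.5-fold higher number from compound 3 to compound 4 (0.19 log units; within the scatter). For compound 4 the estimate is 27000 nM, with an expected range of 16000 nM to 50000 nM.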

Compound 4, half-maximal inhibitory concentration: 22000 nM
For compound 4 the middle estimate is 1.2-fold (0.09 log units) above the measured one, within the range that was stated.
By their numbers in this assay, from the lowest: compounds 3, 4 and 1 (each within the scatter of the next). At a limit, above all of these: compound 2.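

In this assay, the swap to 2,6-dimethylphenyl on the amide-type nitrogen now has a real number on the trifluoromethyl core, and the change is small: a 1.3-fold higher number from compound 3 to compound 4 (0.10 log units; within the scatter). Trifluoromethyl in place of methyl gives an at least 1.3-fold lower number from compound 2 to compound 4 (0.13 log units; that floor lies within the scatter), a step whose true size cannot be read. Compound 2 sits at a limit of the assay, > 30000 nM, so the swap cannot be compared across the two cores: the same change on two cores in this assay, an at least 1.1-fold higher number (0.06 log units; that floor lies within the scatter) from compound 1 to compound 2 and a 1.3-fold higher number (0.10 log units; within the scatter) from compound 3 to compound 4; the limit leaves it open whether they differ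

On these data alone, it remains open whether any group on the amide-type nitrogen moves the number beyond the scatter. A group carrying an amine or a carboxylic acid in place of 2,6-dimethylphenyl would test this.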